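The source may report more compounds than this note shows. Statements on the series, on what has been measured and on what is new or still open speak of the compounds shown alone.

The measured compounds are:

compound 1, `CCC1CCN(c2cc(C(F)(F)F)ccc2CNC(=O)C(C)c2ccc(NS(C)(=O)=O)c(F)c2)CC1`, which in an assay on CHO cells for antagonist activity at transient receptor potential cation channel subfamily V member 1 (Homo sapiens), read by FLIPR (a lower number here means a stronger inhibitor, a higher number a weaker inhibitor), gives 0.7 nM;
compound 2, `CC(C(=O)NCc1ccc(C(F)(F)F)cc1N1CCC(Cc2ccccc2)CC1)c1ccc(NS(C)(=O)=O)c(F)c1`, which in this assay gives 1.4 nM;
compound 3, `CC(C(=O)NCc1ccc(C(F)(F)F)cc1OC1CCCC1)c1ccc(NS(C)(=O)=O)c(F)c1`, which in this assay gives 0.6 nM.

Compound 3 holds the lowest of the three numbers. Its nearest neighbour is compound 1, and the step of a 1.2-fold lower number from compound 1 to compound 3 (0.07 log units; within the scatter) is within the scatter, so the two cannot be told apart. Compound 2 stands further off, and the gap between compound 3 and compound 2 lies beyond the scatter.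

Compound 4, `CC(C(=O)NCc1ccc(C(F)(F)F)cc1-c1ccc(F)c(Cl)c1)c1ccc(NS(C)(=O)=O)c(F)c1`, has not yet been measured in this assay. It differs from compound 3 in one place: 3-chloro-4-fluorophenyl in place of cyclopentyloxy on an aromatic carbon.

Within the data shown here, two measured steps bear on this position. The step of a 1.2-fold lower number from compound 1 to compound 3 (0.07 log units; within the scatter) exchanged one group on that aromatic carbon for another and stayed within the scatter. The step of a 2.0-fold higher number from compound 1 to compound 2 (0.30 log units; within the scatter) altered the group attached there and also stayed within the scatter. Both steps point to a position that tolerates change, although neither involved an aromatic ring entering there, so the expectation rests on limited ground.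

The step of a 2.0-fold higher number from compound 3 to compound 4 (0.30 log units; within the scatter) is therefore expected to stay within the scatter, with a slight lean toward a higher number. Compound 4 is expected to give about 1.2 nM in this assay, with a range from 0.4 nM to 4 nM.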

Compound 4, inhibition constant: 0.6 nM
Beside the measured number, compound 4's estimate is 2.0-fold (0.30 log units) above it; measured number inside the range.
By their numbers in this assay, from the lowest: compounds 3, 4, 1 and 2 (each within the scatter of the next, the first and the last beyond it).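

Among these compounds, with 3-chloro-4-fluorophenyl, an aromatic ring of carbon only now stands on this aromatic carbon, which none of the earlier compounds showed. In this assay the exchange of cyclopentyloxy for this larger group gives no change at the digits printed from compound 3 to compound 4 (within the scatter), and the exchange of 4-ethylpiperidin-1-yl for the same group gives a 1.2-fold lower number from compound 1 to compound 4 (0.07 log units; within the scatter), so three quite different groups at this position, saturated or aromatic and with or without chlorine and fluorine, cannot be told apart in this assay. The evidence at hand offers no account of why these groups read alike.

The compounds shown leave open whether a plain phenyl, carrying neither chlorine nor fluorine, would read the same as 3-chloro-4-fluorophenyl, and so whether either halogen contributes anything at this position. They also leave open whether this tolerance extends to a group of another kind on the same carbon, such as a carboxylic acid, a primary amine or a short chain ending in a hydroxyl group, since every group seen here carries a ring and none of these.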